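The source may report more compounds than this note shows. Statements on the series, on what has been measured and on what is new or still open speak of the compounds shown alone.

Working notes on the series. Compound 3 `CC1Oc2ccc(Br)cc2C=C1/C=C1\SC(=O)NC1=O` gives 77000 nM in a functional assay on K562 cells (Homo sapiens) for antiproliferative activity, read by MTT assay, with a stated time of 72 h (on this read-out lower numbers stand for stronger inhibition and higher numbers for weaker inhibition), the highest of the three numbers in hand; compound 1 `O=C1NC(=O)/C(=C/C2=Cc3cc(Br)ccc3OC2)S1` gives 49800 nM and compound 2 `O=C1NC(=S)S/C1=C\C1=Cc2cc(Br)ccc2OC1` gives 33700 nM. Going by the values given here, the one measured step, a 1.5-fold higher number from compound 1 to compound 3 (0.19 log units; within the scatter), lies within the scatter. Compound 4 `CC1Oc2ccc(Br)cc2C=C1/C=C1\SC(=O)N(C)C1=O` differs from compound 3 by methyl in place of hydrogen on an amide-type nitrogen in a ring. Among the compounds with values here, no measured step touches the amide-type nitrogen, so the only guide is that the single methyl step in this assay moved nothing beyond the scatter. A step within the scatter is therefore expected, the number estimated to sit near or somewhat above that of compound 3, a 1.2-fold higher number from compound 3 to compound 4 (0.07 log units; within the scatter). Compound 4 is estimated at 90000 nM, in the range 30000 nM to 250000 nM, with some chance that only a limit is reported.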

Compound 4, half-maximal inhibitory concentration: > 50000 nM
Compound 4: no number, only a limit; the forecaster's own chance of this, stated with the estimate: 20%; the middle value is on the limit's open side.
By their numbers in this assay, from the lowest: compounds 2, 1 and 3 (each within the scatter of the next, the first and the last beyond it).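

Compound 4 is reported only as the limit > 50000 nM and the step from compound 3 to compound 4 cannot be read. The compounds shown leave open whether methyl in place of hydrogen on the amide-type nitrogen moves the number at all.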